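This account rests on a few compounds, and the source may have more. Where it says the series, first, only, none or still open, it means among the compounds named here.

Compound 1 `Cc1c(O)ccc2c1[C@H](Cn1cc(-c3ccc(Cl)cc3)nn1)[C@@]13CC(=O)[C@@](C)(CC[C@@H]21)C3` in a functional assay on SW480 cells (Homo sapiens) for cytotoxicity, read by MTT assay, with a stated time of 4 days (on this read-out lower numbers stand for stronger inhibition and higher numbers for weaker inhibition), gives > 20000 nM, which is a limit of the assay and not a number. Compound 2 `Cc1ccc(S(=O)(=O)Oc2ccc3c(c2C)[C@H](Cn2cc(-c4ccc(Cl)cc4)nn2)[C@@]24CC(=O)[C@@](C)(CC[C@@H]32)C4)cc1` in this assay gives > 20000 nM, again a limit. The step that the two limits leave unreadable from compound 1 to compound 2 is thus unreadable. Compound 3 `C=C1C(=O)[C@]23C[C@@]1(O)CC[C@H]2c1ccc(O)c(C)c1[C@@H]3Cn1cc(-c2ccccn2)nn1`, which carries a different core, gives 410 nM in this assay. Compound 4 `Cc1c(O)ccc2c1[C@H](Cn1cc(-c3ccccn3)nn1)[C@@]13CC(=O)[C@@](C)(CC[C@@H]21)C3` differs from compound 1 by pyridin-2-yl in place of 4-chlorophenyl on an aromatic carbon. Going by the values given here, no measured step covers this exchange on the core of compound 1; the evidence that remains is the limit of > 20000 nM in this assay, at which 2 of the 3 values shown sit, where compound 1 sits. Compound 4 is therefore expected to stay near that limit, with an estimated step of an at least 1.3-fold lower number from compound 1 to compound 4 (0.12 log units; that floor lies within the scatter). The estimate for compound 4 is 15000 nM, with a range from 3000 nM to 40000 nM.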

Compound 4, half-maximal inhibitory concentration: > 20000 nM
Compound 4: a limit, no number; the forecaster's own chance of this, stated with the estimate: 60%; at least 1.3-fold (0.12 log units) between middle value and limit.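

Going by these compounds alone, compound 4 gives > 20000 nM, a limit and not a number; compound 1 also stands at a limit, so no step between compound 1 and compound 4 can be read. From the compounds shown here alone, what pyridin-2-yl in place of 4-chlorophenyl does on the core of compound 1 stays open, as do the actual values of both compounds.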